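This account rests on a few compounds, and the source may have more. Where it says the series, first, only, none or still open, it means among the compounds named here.

For the measured compounds named here, compound 1 `CC(O)(CSc1ccc(Cl)cc1)c1nc(-c2ccc(Cl)cc2)no1` stands lowest of the two numbers known so far in a functional assay on DU-145 cells (Homo sapiens) for cytotoxicity, read by MTT assay (on this read-out lower numbers stand for stronger inhibition and higher numbers for weaker inhibition), giving 14500 nM. Compound 2 `CC(O)(CS(=O)(=O)c1ccc(Cl)cc1)c1nc(-c2ccc([N+](=O)[O-])c(C(F)(F)F)c2)no1` gives a higher 91000 nM in this assay, a gap beyond the usual scatter. Compound 3 `CC(O)(CSc1ccc(Cl)cc1)c1nc(-c2ccc(F)c(Cl)c2)no1` differs from compound 1 in a single place: 3-chloro-4-fluorophenyl in place of 4-chlorophenyl on an aromatic carbon. Going by the values given here, no measured pair with this kind of change is known, so the step of a 1.2-fold lower number from compound 1 to compound 3 (0.08 log units; within the scatter) is expected to be small, in no sure direction, and probably within the scatter. Compound 3 is therefore estimated at 12000 nM in this assay, within a range from 4000 nM to 40000 nM.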

Compound 3, half-maximal inhibitory concentration: 500 nM
The estimate for compound 3 lay 24-fold (1.38 log units) above the measured number; the measured number lies below the stated range.
By their numbers in this assay, from the lowest: compound 3; then compound 1; then compound 2.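

In this assay the swap of 4-chlorophenyl for 3-chloro-4-fluorophenyl, on the aromatic carbon between two ring nitrogen atoms, gives a 29-fold lower number from compound 1 to compound 3 (1.46 log units; beyond the scatter) and so shows that this position responds strongly to a change in the halogens on the phenyl ring. The earlier compounds shown here, which differ in more than one place, could not show this for any single position. Nothing at hand accounts for the size of this step.

As far as these compounds go, it remains open whether the 3-chloro or the 4-fluoro part of the new group carries the step, and whether a methoxy group or a nitrile on this phenyl ring would serve as well.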